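A few compounds are considered here, and "the series" means these few. Any claim that something is new, unique, unknown or untested is made for them only; others in the source may bear on it.

Measured compounds:
compound 1 `Cc1c[se]c(N/N=C/c2ccc(Cl)cc2)n1` — in a functional assay on DU-145 cells (Homo sapiens) for cytotoxicity, read by XTT assay, with a stated time of 72 h (a higher number here means a weaker inhibitor, a lower number a stronger inhibitor), compound 1 gives 49400 nM.
compound 2 `ClCc1c[se]c(N/N=C/c2ccc(Cl)cc2)n1` — in this assay compound 2 gives > 75000 nM, which is a limit of the assay and not a number.

Compound 2 thus stands at the limit of > 75000 nM in this assay, at which 1 of the 2 values shown sits. Among the measured compounds shown here, the step of an at least 1.5-fold higher number from compound 1 to compound 2 (0.18 log units; that floor lies within the scatter) is the only measured step and rests on that limit. Compound 3 `Clc1ccc(/C=N/Nc2nc(-c3ccccc3)c[se]2)cc1` differs from compound 2 by phenyl in place of chloromethyl on an aromatic carbon. For the measured compounds named here, no measured step covers a phenyl at this place, so the expectation in this assay rests on the two values alone, with compound 1 as the only number. Compound 3 is estimated at 50000 nM, between 15000 nM and 150000 nM. The expected step of an at least 1.5-fold lower number from compound 2 to compound 3 (0.17 log units; that floor lies within the scatter) is accordingly small, and a limit is again possible.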

Compound 3, half-maximal inhibitory concentration: 54200 nM
Compound 3: the middle estimate sits 1.1-fold (0.04 log units) below what was measured; the measured number falls inside the stated range.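

In this assay, phenyl in place of methyl on this aromatic carbon, next to the ring nitrogen, gives a 1.1-fold higher number from compound 1 to compound 3 (0.04 log units; within the scatter), so a six-membered aromatic ring of carbon only is carried at this place without a change beyond the scatter. The other step, an at least 1.3-fold lower number from compound 2 to compound 3 (0.14 log units; that floor lies within the scatter), is a floor that rests on a limit and not a number: the limit of > 75000 nM in this assay, at which 1 of the 3 values shown sits.

Still open, as far as these compounds go, is whether an amine, a carboxylic acid or a longer chain at this place would give a value beyond the scatter from that of compound 1.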